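The source may hold more compounds than are shown below. What is called first, only, known or untested is meant among the compounds shown, and "the series" means these compounds.

For the measured compounds named here, compound 2 `O=C(Nc1cc(Oc2ccc(Nc3nccc4[nH]cc(-c5ccc(F)cc5)c(=O)c34)cc2F)ccn1)C1CC1` gives 81.8% in a functional assay on MKN-45 cells (Homo sapiens) for antiproliferative activity, read by MTT assay, with a stated time of 72 h, tested at 10 uM (on this read-out higher numbers stand for more inhibition at the one concentration tested (going by the name of the read-out) and lower numbers for less inhibition), the second highest of the three numbers so far. Compound 3 `Nc1nccc(Oc2ccc(Nc3nccc4[nH]cc(-c5ccc(F)cc5)c(=O)c34)cc2F)c1Cl` gives 85.7% in this assay, and the step of a number 3.9 percentage points higher from compound 2 to compound 3 (within the scatter) stays within the scatter. Compound 1 `CCn1cc(-c2ccc(F)cc2)c(=O)c2c(Nc3ccc(Oc4ccnc(NC(=O)C5CC5)c4)c(F)c3)nccc21` gives 31.9% in this assay, the step of a number 49.9 percentage points higher from compound 1 to compound 2 (beyond the scatter) being the only large one in the set.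

Compound 4 `CC(C)(O)C(=O)Nc1cc(Oc2ccc(Nc3nccc4[nH]cc(-c5ccc(F)cc5)c(=O)c34)cc2F)ccn1` differs from compound 2 by 1-hydroxy-1-methylethyl in place of cyclopropyl on a carbonyl carbon. Going by the values given here, no measured step alters the group on the carbonyl carbon; the nearest guide is the exchange of the whole amide end in the step of a number 3.9 percentage points higher from compound 2 to compound 3 (within the scatter), which moved the number little. A step of no more than the scatter is therefore expected, a number 3.8 percentage points lower from compound 2 to compound 4 (within the scatter), and compound 4 is estimated at 78% with a range of 62% to 92%.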

Compound 4, a percentage reported as inhibition, at one concentration (the size of the read-out at that concentration, not a potency): 57.8%
Beside the measured number, compound 4's estimate is 20.2 percentage points above it; the whole stated range lies above it.
By their numbers in this assay, from the lowest: compound 1; then compound 4; then compounds 2 and 3 (each within the scatter of the next).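

In this assay, 1-hydroxy-1-methylethyl in place of cyclopropyl on the carbonyl carbon gives a number 24 percentage points lower from compound 2 to compound 4 (beyond the scatter). The number therefore responds to the group on this carbon, which a number 3.9 percentage points higher from compound 2 to compound 3 (within the scatter), an exchange of the whole amide end, gave no sign of. No measurement in hand accounts for this step.

The compounds shown do not separate the effect of the hydroxyl from that of losing the cyclopropyl ring. A tert-butyl group on the same carbonyl carbon would keep the branching without the hydroxyl and so test that question.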